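Sulfonyl to Carbamoyl Swap on a Piperazine Nitrogen

The compounds below may be only part of what the source reports. "The series", "measured", "known", "first", "only" and "open" are said of these compounds alone.

Measured compounds:
compound 1 `C=CS(=O)(=O)N1CCN(c2ncnc3sc(-c4cc(Br)cnc4F)cc23)CC1` gives 28400 nM in a functional assay on MDA-MB-436 cells (Homo sapiens) for antiproliferative activity, read by MTT assay, with a stated time of 48 h; a lower number here means a stronger inhibitor, a higher number a weaker inhibitor
compound 2 `CN1CCN(c2ccc(-c3cc4c(N5CCN(S(=O)(=O)C6CC6)CC5)ncnc4s3)cc2)CC1` gives 10600 nM in this assay

Of these two, compound 2 has the lower number, and its gap to compound 1 lies beyond the scatter. Compound 3 `CN1CCN(c2ccc(-c3cc4c(N5CCN(C(=O)Nc6ccc(F)cc6F)CC5)ncnc4s3)cc2)CC1` is not yet measured. It differs from compound 2 in one place: (2,4-difluorophenyl)carbamoyl in place of cyclopropylsulfonyl on an amine nitrogen in a ring. Going by the values given here, no measured pair shows this change, so its effect is open. A step from compound 2 to compound 3 of modest size toward a lower number is expected, a 1.8-fold lower number from compound 2 to compound 3 (0.25 log units; within the scatter), though staying within the scatter is also plausible. Compound 3 is estimated at 6000 nM, with a range from 1500 nM to 25000 nM.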

Compound 3, half-maximal inhibitory concentration: 20200 nM
Compound 3: the middle estimate sits 3.4-fold (0.53 log units) below what was measured; measured number inside the range.
By their numbers in this assay, from the lowest: compounds 2, 3 and 1 (each within the scatter of the next, the first and the last beyond it).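

Swapping cyclopropylsulfonyl for (2,4-difluorophenyl)carbamoyl on the amine nitrogen in a ring gives a 1.9-fold higher number from compound 2 to compound 3 (0.28 log units; within the scatter) in this assay, so this step cannot be told apart from repeat-measurement noise. At this position, then, a sulfonyl group and a much larger carbamoyl group carrying an aromatic ring and a hydrogen-bond donor give similar numbers. No measurement here explains this result. Still open, as far as these compounds go, is how a small acetyl group, a simple unsubstituted phenylcarbamoyl group, or a free ring amine would read at this nitrogen.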